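The compounds below may be only part of what the source reports. "The series", "measured", "known", "first", "only" and "open" are said of these compounds alone.

Compound 1, `Cn1c(SCC(=O)Nn2c(COc3ccc(Cl)cc3Cl)nc3ccccc3c2=O)nc(-c2ccc(Cl)cc2)c(C#N)c1=O`, gives 73.7%.
Compound 2, `N#Cc1c(-c2ccc(Cl)cc2)nc(SCC(=O)Nn2c(COc3ccc(Cl)cc3Cl)nc3ccccc3c2=O)n(Cc2ccccc2)c1=O`, gives 77.2%.
Compound 3, `Cn1c(SCC(=O)Nn2c(COc3ccc(Cl)cc3Cl)nc3ccccc3c2=O)nc(-c2ccc(O)cc2)c(C#N)c1=O`, gives 86%.

All three were tested in a functional assay on the whole organism (strain albino) for inhibition, with Rattus norvegicus as the target, read by paw edema, with stated times of 1 h and 3 h, at a dose of 100 mg/kg by the oral route; on this read-out lower numbers stand for a weaker effect and higher numbers for a stronger effect at the one dose given. Compound 2 differs from compound 1 by phenyl in place of hydrogen on a saturated chain carbon bound to an aromatic nitrogen, and that change gave a number 3.5 percentage points higher from compound 1 to compound 2 (within the scatter). Compound 3 differs from compound 1 by hydroxy in place of chloro on an aromatic carbon, and that gave a number 12.3 percentage points higher from compound 1 to compound 3 (beyond the scatter). Compound 4, `N#Cc1c(-c2ccc(O)cc2)nc(SCC(=O)Nn2c(COc3ccc(Cl)cc3Cl)nc3ccccc3c2=O)n(Cc2ccccc2)c1=O`, is not yet measured in this assay. It carries the same change as compound 2 does relative to compound 1, namely (phenyl in place of hydrogen on a saturated chain carbon bound to an aromatic nitrogen), but on the core of compound 3; the two cores differ in the way compound 3 differs from compound 1.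

Because that change once gave a number 3.5 percentage points higher from compound 1 to compound 2 (within the scatter), a similarly small step is expected in this assay, namely a number 3 percentage points higher from compound 3 to compound 4 (within the scatter). Compound 4 is thus estimated at 89%, with a likely range from 79% to 96%.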

Compound 4, a percentage reported as inhibition, in the whole organism at one dose (the size of the read-out at that dose, not a potency): 61.4%
The estimate for compound 4 lay 27.6 percentage points above the measured number, and the stated range ends above it.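

In this assay, methyl to benzyl on the core of compound 3 gave a number 24.6 percentage points lower from compound 3 to compound 4 (beyond the scatter), so this change did not carry over from one core to the other: the same change on two cores in this assay, a number 3.5 percentage points higher (within the scatter) from compound 1 to compound 2 and a number 24.6 percentage points lower (beyond the scatter) from compound 3 to compound 4, 28.1 percentage points apart, beyond the scatter of two such steps.
Hydroxy in place of chloro likewise gave a number 15.8 percentage points lower from compound 2 to compound 4 (beyond the scatter), and its effect depended on the core as well: the same change on two cores in this assay, a number 12.3 percentage points higher (beyond the scatter) from compound 1 to compound 3 and a number 15.8 percentage points lower (beyond the scatter) from compound 2 to compound 4, 28.1 percentage points apart, beyond the scatter of two such steps.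
These four compounds show that the two changes do not simply add up here, but they do not show why, and they cannot tell how far this holds beyond this single set of compounds.

As far as these compounds go, it remains open how an ethyl group or a longer chain would behave in place of benzyl. An amine or a methoxy group in place of hydroxy is also left open.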